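The compounds below may be only part of what the source reports. "The series", "measured", "known", "first", "only" and "open" are said of these compounds alone.

Measured so far in a functional assay on A549 cells (Homo sapiens) for cytotoxicity, read by MTT assay, with a stated time of 72 h; a higher number here means that more compound is needed for the effect, a lower number that less compound is needed:
Compound 1, `CCS[C@@H]1[C@H](SCC)[C@@H](Cn2cc(-c3ccccc3)nn2)O[C@H]1n1ccc(=O)[nH]c1=O`: compound 1 gives 3040 nM.
Compound 2, `CCS[C@@H]1[C@H](SCC)[C@@H](Cn2cc(-c3ccccc3C(F)(F)F)nn2)O[C@H]1n1ccc(=O)[nH]c1=O`: compound 2 gives 19400 nM.
Compound 3, `CCS[C@@H]1[C@H](SCC)[C@@H](Cn2cc(COC(C)=O)nn2)O[C@H]1n1ccc(=O)[nH]c1=O`: compound 3 gives >= 100000 nM, which is a limit of the assay and not a number.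

Of the two compounds with a number in this assay, compound 2 stands highest, and compound 1 is its nearest neighbour; the step of a 6.4-fold higher number from compound 1 to compound 2 (0.80 log units; beyond the scatter) lies beyond the scatter. Compound 3 sits at the limit of >= 100000 nM in this assay, at which 1 of the 3 values shown sits.

Compound 4, `CCS[C@@H]1[C@H](SCC)[C@@H](Cn2cc(-c3cccs3)nn2)O[C@H]1n1ccc(=O)[nH]c1=O`, has not yet been measured. It differs from compound 2 in one place: thiophen-2-yl in place of 2-(trifluoromethyl)phenyl on an aromatic carbon. Among the measured compounds shown here, three measured steps bear on this change. Adding trifluoromethyl to the phenyl ring gave a 6.4-fold higher number from compound 1 to compound 2 (0.80 log units; beyond the scatter). Exchanging the whole aryl group for acetoxymethyl gave an at least 5.1-fold higher number from compound 2 to compound 3 (0.71 log units; beyond the scatter) and an at least 32-fold higher number from compound 1 to compound 3 (1.51 log units; beyond the scatter). Compound 4 keeps an aromatic ring at this position but drops the trifluoromethyl, so it resembles compound 1 more closely than compound 3 does. In this assay a lower number is therefore expected for compound 4, roughly undoing the rise seen on going to compound 2, as a 4.9-fold lower number from compound 2 to compound 4 (0.69 log units; beyond the scatter). Compound 4 is estimated at 4000 nM, with a likely range from 1500 nM to 15000 nM.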

Compound 4, half-maximal effective concentration: >= 100000 nM
Compound 4: a limit, no number; the forecaster's own chance of this, stated with the estimate: 5%; middle value at least 25-fold (1.39 log units) away from the limit.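

Compound 4 gives a limit of the assay and not a number, and it now shares that limit with compound 3: the limit of >= 100000 nM in this assay, at which 2 of the 4 values shown sit.

Keeping an aromatic ring at this carbon is therefore not enough to give a measurable number in this assay: thiophen-2-yl in place of 2-(trifluoromethyl)phenyl gives an at least 5.1-fold higher number from compound 2 to compound 4 (0.71 log units; beyond the scatter), and thiophen-2-yl in place of phenyl gives an at least 32-fold higher number from compound 1 to compound 4 (1.51 log units; beyond the scatter). Among the four compounds shown, only the two with a six-membered aromatic ring of carbon only give a number, so this position separates one aromatic ring from another, while the step between compound 3 and compound 4 cannot be read.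

The compounds shown leave open whether the ring size or the sulfur atom of thiophen-2-yl sets compound 4 apart from compound 1, and a furan-2-yl or a pyridine ring at this carbon would help to separate the two. They also leave open how a phenyl ring carrying a smaller group, such as a methoxy group or an amine, would compare with the phenyl of compound 1.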